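This account rests on a few compounds, and the source may have more. Where it says the series, first, only, none or still open, it means among the compounds named here.

In a physicochemical assay for solubility, read by HPLC, in phosphate buffer, measured as kinetic solubility, with a stated time of 1 h, at pH 7.4, tested at 250 uM (a lower number here means a less soluble compound, a higher number a more soluble compound), compound 3 `CC(C)CNC(=O)n1c(=O)oc2cc(C3CCN(C)CC3)ccc21` gives 240000 nM. This is level, within the scatter, with compound 2 `CC(C)CNC(=O)n1c(=O)oc2cc(C3CCCCN3C)ccc21` at 190000 nM, and well clear of compound 1 `CN1CCC(c2ccc3c(c2)oc(=O)n3C(=O)NCCCCc2ccc(F)cc2)CC1` at 22000 nM. The next analogue, compound 4 `CCCCCNC(=O)n1c(=O)oc2cc(C3CCN(C)CC3)ccc21`, differs from compound 3 in one place: butyl in place of isopropyl on a saturated chain carbon bound to an amide-type nitrogen. Cut one bond further out, the same difference reads isobutyl to pentyl. Among the compounds with values here, the only measured step at this place is large: an 11-fold higher number from compound 1 to compound 3 (1.04 log units; beyond the scatter). The present exchange is far smaller than that one, so only a modest share of that step is expected, pointing to a lower number in this assay. The other measured step, a 1.3-fold higher number from compound 2 to compound 3 (0.10 log units; within the scatter), lies within the scatter and sits on an aromatic carbon, so it offers no guide here. The expected step is a 1.8-fold lower number from compound 3 to compound 4 (0.27 log units; within the scatter). Compound 4 is estimated at 130000 nM, with an expected range of 55000 nM to 240000 nM.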

Compound 4, solubility: 240000 nM
Estimate against measurement, compound 4: 1.8-fold (0.27 log units) below; the range from low to high includes it.
By their numbers in this assay, from the lowest: compound 1; then compounds 2, 3 and 4 (each within the scatter of the next).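

In this assay, within the data shown here, butyl in place of isopropyl on a saturated chain carbon bound to an amide-type nitrogen gives no change at the digits printed from compound 3 to compound 4 (within the scatter), the first step at this position that is not large, so a modest lengthening of the alkyl chain here leaves the number in place. With methyl in place of 4-fluorophenyl at the chain end, the series shows an 11-fold higher number from compound 1 to compound 4 (1.04 log units; beyond the scatter), which ties the large step at this position to that change rather than to alkyl chain growth as far as pentyl. No supporting data bear on this result.

Still open, on these data alone, is whether a longer alkyl chain such as octyl, or an unsubstituted phenyl at the chain end, would hold the number or lower it. As far as these compounds go, a chain ending in a hydroxyl group or a carboxylic acid is equally open.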